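A few compounds are considered here, and "the series" means these few. Any claim that something is new, unique, unknown or untested is made for them only; others in the source may bear on it.

Series notes. In an in vitro functional assay on HEK293-A cells for positive allosteric modulation of metabotropic glutamate receptor 5 (Homo sapiens), read by FLIPR and calcium flux (a lower number here means that less compound is needed, a higher number that more compound is needed for the effect), compound 1 `O=C1CC(c2nc(-c3ccc(F)cc3)no2)CN1c1ccc(Cl)cc1` gives 1700 nM. Compound 2 `O=C1CC(c2nc(-c3cccc(Cl)c3)no2)CN1c1ccc(Cl)c(Cl)c1` gives 460 nM in this assay. Compound 3 `Cc1cccc(N2CC(c3nc(-c4cccc(Cl)c4)no3)CC2=O)c1` is reported only as a limit of this assay, > 10000 nM. On the numbers shown, compound 3 therefore stands at the limit of > 10000 nM in this assay, at which 1 of the 3 values shown sits, without a number of its own, and the step of an at least 21-fold higher number from compound 2 to compound 3 (1.33 log units; beyond the scatter) places it well apart from compound 2.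

Compound 4 `Cc1ccccc1N1CC(c2nc(-c3cccc(Cl)c3)no2)CC1=O` differs from compound 3 in one place: 2-methylphenyl in place of 3-methylphenyl on an amide-type nitrogen in a ring. Of the measured steps only one touches the same amide-type nitrogen in a ring, an at least 21-fold higher number from compound 2 to compound 3 (1.33 log units; beyond the scatter), and that step sets a dichlorinated ring against the methyl ring rather than two methyl rings against each other. Within the data shown here, no measured step shows what moving the methyl within the ring does, so no direction is supported, and compound 3 itself offers only a limit to start from. The expectation for compound 4 is thus a number close to that limit with a wide range either way: compound 4 is estimated at 12000 nM (range 3000 nM to 40000 nM), which as a step means a step that the limit leaves unreadable from compound 3 to compound 4 is expected, with a real chance that only a limit is reported again.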

Compound 4, half-maximal effective concentration: > 10000 nM
Compound 4: no number, only a limit (the forecaster's own chance of this, stated with the estimate: 60%); the middle value is on the limit's open side.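

Moving the methyl from 3-methylphenyl to 2-methylphenyl on the amide-type nitrogen in a ring does not bring a readable number back in this assay for this series, since compound 4, like compound 3, is reported only as a limit, and the steps that rest on two limits cannot be read. Set against the dichlorinated ring, the 2-methylphenyl change gives an at least 21-fold higher number from compound 2 to compound 4 (1.33 log units; beyond the scatter) as a second large step at this nitrogen, so both methylphenyl rings shown stand well apart from compound 2. Neither placement of the methyl shown gives a value inside the readable range, and the two compounds share one end of the assay: the limit of > 10000 nM in this assay, at which 2 of the 4 values shown sit.

On these data alone, how far compound 3 and compound 4 lie past that limit stays open, so the two methyl placements cannot be ranked against each other. Also open, as far as these compounds go, is whether a methoxy or a trifluoromethyl group on this phenyl ring would restore a readable number, and whether such a group would come close to the dichlorinated ring of compound 2.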